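The compounds below may be only part of what the source reports. "The series", "measured", "known", "first", "only" and "open" are said of these compounds alone.

Measured compounds:
compound 1 `O=C(c1cccc(F)c1)N(/N=N/c1ccc([N+](=O)[O-])cc1Cl)c1ccc([N+](=O)[O-])cc1Cl`, 2500 nM
compound 2 `O=C(c1ccccc1F)N(/N=N/c1ccc([N+](=O)[O-])cc1C(F)(F)F)c1ccc([N+](=O)[O-])cc1C(F)(F)F`, 800 nM
compound 3 `O=C(c1ccccc1C(F)(F)F)N(/N=N/c1ccc([N+](=O)[O-])cc1C(F)(F)F)c1ccc([N+](=O)[O-])cc1C(F)(F)F`, 5350 nM

In a functional assay on HeLa cells (Homo sapiens) for cytotoxicity, read by MTT assay, with a stated time of 72 h (on this read-out lower numbers stand for stronger inhibition and higher numbers for weaker inhibition), compound 3 gives 5350 nM, the highest of the three numbers; compound 1 comes nearest and compound 2 lies furthest away. Compound 4 `O=C(c1cccc(F)c1)N(/N=N/c1ccc([N+](=O)[O-])cc1C(F)(F)F)c1ccc([N+](=O)[O-])cc1C(F)(F)F` is not yet measured. It differs from compound 3 by 3-fluorophenyl in place of 2-(trifluoromethyl)phenyl on a carbonyl carbon. Among the compounds with values here, one measured step bears on this change: a 6.7-fold higher number from compound 2 to compound 3 (0.83 log units; beyond the scatter), where a trifluoromethyl took the place of a fluoro on the aromatic ring of that benzoyl group. Compound 4 removes that trifluoromethyl again and carries a fluoro instead, though at a different position, so the earlier step is partly reversed. Compound 1 shares the 3-fluorophenyl carbonyl but has chloro rather than trifluoromethyl on its other two rings; its value and that of compound 3 show only a modest gap. A lower number is therefore expected for compound 4, as a 4.1-fold lower number from compound 3 to compound 4 (0.61 log units; beyond the scatter). The estimate for compound 4 is 1300 nM, within 450 nM to 4000 nM.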

Compound 4, half-maximal inhibitory concentration: 880 nM
Beside the measured number, compound 4's estimate is 1.5-fold (0.17 log units) above it, and the stated range covers the measured number.
By their numbers in this assay, from the lowest: compounds 2 and 4 (each within the scatter of the next); then compound 1; then compound 3.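

In this assay, replacing 2-(trifluoromethyl)phenyl with 3-fluorophenyl on the carbonyl carbon gives a 6.1-fold lower number from compound 3 to compound 4 (0.78 log units; beyond the scatter), so the high number of compound 3 does not carry over to this second fluoro-bearing group. The comparison of the two fluoro groups gives a 1.1-fold higher number from compound 2 to compound 4 (0.04 log units; within the scatter), which lies within the scatter, so 2-fluorophenyl and 3-fluorophenyl cannot be told apart at this place, and among the three groups compared here on this carbonyl carbon only 2-(trifluoromethyl)phenyl stands apart. No measurement shown here offers an explanation for this difference.

The compounds shown leave open whether the high number follows from trifluoromethyl itself or from where it sits on the ring. They also leave open how an unsubstituted phenyl, or a phenyl carrying a methoxy group or an amine, would read at this carbonyl carbon.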